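The source may hold more compounds than are shown below. What is called first, only, known or untested is meant among the compounds shown, and "the series" means these compounds.

Working notes on the series. Three compounds carry numbers in a functional assay on HeLa cells (Homo sapiens) for cytotoxicity, read by MTT assay, with a stated time of 48 h; a lower number here means a stronger inhibitor, a higher number a weaker inhibitor. Compound 1 `O=c1ccoc2cc(OCc3cn(Cc4ccccc4)nn3)ccc12` has only a limit of the assay in this assay: compound 1 gives > 100000 nM. Compound 2 `O=c1ccoc2cc(OCc3cn(Cc4cccc(F)c4)nn3)ccc12` gives 7550 nM in this assay. Compound 3 `N#Cc1ccc(Cn2cc(COc3ccc4c(=O)ccoc4c3)nn2)cc1` likewise sits at a limit in this assay: compound 3 gives > 100000 nM. Compound 3 therefore stands at the limit of > 100000 nM in this assay, at which 2 of the 3 values shown sit, with no number of its own.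

The measured steps: fluoro in place of hydrogen on an aromatic carbon gives an at least 13-fold lower number from compound 1 to compound 2 (1.12 log units; beyond the scatter); cyano in place of hydrogen gives a step that the two limits leave unreadable from compound 1 to compound 3; 4-cyanophenyl in place of 3-fluorophenyl gives an at least 13-fold higher number from compound 2 to compound 3 (1.12 log units; beyond the scatter).

The next compound, compound 4 `COc1ccc(Cn2cc(COc3ccc4c(=O)ccoc4c3)nn2)cc1`, differs from compound 3 by methoxy in place of cyano on an aromatic carbon. Among the compounds with values here, no measured step swaps one substituent for another at this place; the steps that bear on it only show that compound 3 and compound 1 both sit at the limit while compound 2 gives a number. A step toward a stronger inhibitor is possible but unsupported, so compound 4 is expected to stay near the limit, with an expected step of an at least 1.2-fold lower number from compound 3 to compound 4 (0.09 log units; that floor lies within the scatter). Compound 4 is estimated at 80000 nM, between 15000 nM and 400000 nM.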

Compound 4, half-maximal inhibitory concentration: 14400 nM
Estimate against measurement, compound 4: 5.6-fold (0.74 log units) above; measured number below the stated range.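

In this assay, the substituent on the aromatic carbon para to a large group decides whether a number can be read at all: methoxy in place of cyano gives an at least 6.9-fold lower number from compound 3 to compound 4 (0.84 log units; beyond the scatter), and methoxy in place of hydrogen gives an at least 6.9-fold lower number from compound 1 to compound 4 (0.84 log units; beyond the scatter). A readable number is also no longer confined to the 3-fluorophenyl compound: 4-methoxyphenyl in place of 3-fluorophenyl gives a 1.9-fold higher number from compound 2 to compound 4 (0.28 log units; within the scatter), so compound 2 and compound 4 cannot be ordered, and two different substitution places on the phenyl ring both give readable values. The two steps toward compound 4 fix only a floor on their size, because compound 1 and compound 3 each rest on a limit of the assay and not on a number: the limit of > 100000 nM in this assay, at which 2 of the 4 values shown sit.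

The compounds shown leave open how an amine, a carboxylic acid or a longer alkoxy chain would read in this assay at this same position, so two substituents with readable outcomes cannot yet define a trend there. Also open, as far as these compounds go, is whether fluoro and methoxy together on one phenyl ring would give a number different from those of compound 2 and compound 4.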